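The source may report more compounds than this note shows. Statements on the series, on what has been measured and on what is new or still open speak of the compounds shown alone.

Going by the values given here, in a functional assay on MC-38 cells (Mus musculus) for antiproliferative activity, read by CCK-8 assay, with a stated time of 48 h (a higher number here means a weaker inhibitor, a lower number a stronger inhibitor), compound 2 (`COc1ccc(/C=C\c2cc(OC)c(OC)c(OC)c2)cc1OCc1ccc(CN2CC[C@@H](O)C2)cc1`) gives 6900 nM as the only actual number so far. Compound 1 (`COc1ccc(/C=C\c2cc(OC)c(OC)c(OC)c2)cc1OCc1ccc(CN[C@H](C(=O)O)[C@H](C)O)cc1`) gives > 10000 nM in this assay and that value is a limit of the assay. Compound 3 (`COc1ccc(/C=C\c2cc(OC)c(OC)c(OC)c2)cc1OCc1ccc(CN[C@H](C(=O)O)[C@@H](C)O)cc1`) is still unmeasured. Its change from compound 2 is (1-carboxy-2-hydroxypropyl)amino in place of 3-hydroxypyrrolidin-1-yl on a saturated chain carbon bound to an aromatic carbon and amounts to (1-carboxy-2-hydroxypropyl)amino in place of 3-hydroxypyrrolidin-1-yl on a saturated chain carbon bound to an aromatic carbon. Among the compounds with values here, one measured step bears on this exchange, running the opposite way. Read backwards, an at least 1.4-fold lower number from compound 1 to compound 2 (0.16 log units; that floor lies within the scatter) points to a rise in the number in this assay and, being a floor within the scatter, supports only a small one. The expected move is a 1.7-fold higher number from compound 2 to compound 3 (0.24 log units; within the scatter) and no larger than the scatter, with a reading at the limit quite possible. Compound 3 is estimated at 12000 nM with an expected range from 6000 nM to 30000 nM in this measurement.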

Compound 3, half-maximal inhibitory concentration: > 10000 nM
Compound 3 ended at the assay's limit; the forecaster's own chance of this, stated with the estimate: 60%; the middle value is on the limit's open side.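

In this assay, exchanging the 3-hydroxypyrrolidin-1-yl group for the (1-carboxy-2-hydroxypropyl)amino group gives an at least 1.4-fold higher number from compound 2 to compound 3 (0.16 log units; that floor lies within the scatter), so only a floor can be read for this exchange. Compound 3 gives > 10000 nM, which is a limit of the assay. The new result shows that the other drawn configuration at the saturated chain carbon also brings no number into view, yet the step between the two forms cannot be read, and two facts limit the comparison: the limit of > 10000 nM in this assay, at which 2 of the 3 values shown sit, and (the fact that compounds 1 and 3 differ only in the configuration as drawn).

On these data alone, how far either acid-bearing compound lies past the limit remains open. Also open, as far as these compounds go, is whether a plain (2-hydroxypropyl)amino group, without the carboxylic acid, or a pyrrolidine without the hydroxyl would give a measurable number at this position.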